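Series notes: aryloxy variation on the shared core

The source may hold more compounds than are shown below. What is called first, only, known or untested is meant among the compounds shown, and "the series" means these compounds.

Measured in an ADME assay on PBMC cells (Homo sapiens) for cytotoxicity; a lower number here means that less compound is tolerated, a higher number that more compound is tolerated:
compound 1 `CC(CCNC(=O)c1c(Cl)cncc1Cl)N1CCC(C(Oc2cccc(C#N)n2)c2ccc(C(F)(F)F)cc2)CC1` gives 15700 nM
compound 2 `Cc1cccc(OC(c2ccc(Br)cc2)C2CCN(C(C)CCNC(=O)c3c(Cl)cncc3Cl)CC2)n1` gives 6500 nM

Among the two numbers so far, compound 1 stands highest in this assay; compound 2 sits lower, and the gap between them is beyond the usual scatter. Within the data shown here, compound 2 differs from compound 1 in more than one place, so the two values show only that the pair spans a real gap, not which change carries it.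

Compound 3 `CC(CCNC(=O)c1c(Cl)cncc1Cl)N1CCC(C(Oc2ccccc2C(F)(F)F)c2ccc(C(F)(F)F)cc2)CC1` is not yet measured in this assay. It differs from compound 1 in one place: 2-(trifluoromethyl)phenyl in place of 6-cyanopyridin-2-yl on an oxygen on a saturated carbon. Among the measured compounds shown here, no measured pair isolates this change, so the direction of the step in this assay is open. For the measured compounds named here, a modest step is expected, if anything toward a lower number, given that the only other compound measured, compound 2, gives 6500 nM, below compound 1. For compound 3 the expected step from compound 1 is a 1.6-fold lower number from compound 1 to compound 3 (0.20 log units; within the scatter), and the estimate for compound 3 in this assay is 10000 nM, with a range from 4000 nM to 25000 nM.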

Compound 3, half-maximal cytotoxic concentration: 12500 nM
Compound 3: the middle estimate sits 1.3-fold (0.10 log units) below what was measured; low and high end bracket the measured number.
By their numbers in this assay, from the lowest: compounds 2, 3 and 1 (each within the scatter of the next, the first and the last beyond it).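

In this assay, among these compounds, 2-(trifluoromethyl)phenyl in place of 6-cyanopyridin-2-yl on an oxygen on a saturated carbon gives a 1.3-fold lower number from compound 1 to compound 3 (0.10 log units; within the scatter) as the only step so far that isolates this position. The exchange swaps a nitrile-bearing aromatic ring with a hetero atom for a carbon-only aromatic ring without hydrogen-bond acceptors, and the read-out shows no change that can be told from scatter, so this pair gives no sign that the position governs cytotoxicity. No measured property of these groups is at hand to account for this result.

As far as these compounds go, whether the read-out stays level with an amine or a carboxylic acid on the aryloxy group remains open. Which of the places where compound 2 differs from compound 1 carries the gap between them also remains unresolved.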